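A few compounds are considered here, and "the series" means these few. Any claim that something is new, unique, unknown or untested is made for them only; others in the source may bear on it.

Working notes on the series.

Compound 1 `CCSc1ncnc2c1ncn2[C@@H]1O[C@H](CO)[C@@H](O)[C@H]1O` sits at 57500 nM in an assay on isolated protein for binding affinity to Equilibrative nucleoside transporter 1 (Homo sapiens); a lower number here means a stronger inhibitor, a higher number a weaker inhibitor. Compound 2 `OC[C@H]1O[C@@H](n2cnc3c(CSc4cccc(Cl)c4)ncnc32)[C@H](O)[C@@H]1O` gives 282 nM in this assay, reached by a 200-fold lower number from compound 1 to compound 2 (2.31 log units; beyond the scatter). Among the compounds with values here, of the two numbers so far, compound 2 carries the lower one, with compound 1 the only neighbour.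

Compound 3 `OC[C@H]1O[C@@H](n2cnc3c(CSc4ccc(Br)cc4)ncnc32)[C@H](O)[C@@H]1O` has not been measured in this assay. It differs from compound 2 by 4-bromophenyl in place of 3-chlorophenyl on a sulfur. Within the data shown here, the one measured step, a 200-fold lower number from compound 1 to compound 2 (2.31 log units; beyond the scatter), replaces a short chain with a halogenated aromatic group and so shows the weight of that whole group, but no measured pair separates the kind of halogen or its place on the ring. Compound 3 keeps a halogenated phenyl on the sulfur, so the step is expected to stay within the scatter, as a 1.2-fold higher number from compound 2 to compound 3 (0.09 log units; within the scatter). For compound 3 the estimate in this assay is 350 nM, with a range from 100 nM to 1200 nM.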

Compound 3, half-maximal inhibitory concentration: 178 nM
The estimate for compound 3 lay 2.0-fold (0.29 log units) above the measured number; low and high end bracket the measured number.
By their numbers in this assay, from the lowest: compounds 3 and 2 (each within the scatter of the next); then compound 1.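

In this assay, 4-bromophenyl in place of 3-chlorophenyl on the sulfur gives a step within the scatter (a 1.6-fold lower number from compound 2 to compound 3 (0.20 log units; within the scatter)), so this pair shows that the halogen and its ring place can change together without a readable shift. The large step from the ethylsulfanyl compound also holds for a second halogenated phenyl (a 320-fold lower number from compound 1 to compound 3 (2.51 log units; beyond the scatter)), so it is not confined to the 3-chlorophenyl group. Nothing available explains either step.

Halogen and ring place change together in this pair, so their separate contributions cannot be read, and either could offset the other. Compounds 2 and 3 both carry a halogen on the phenyl ring, which leaves open how an unsubstituted phenyl, a methoxy group, an amine or a carboxylic acid there would compare.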